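A few compounds are considered here, and "the series" means these few. Any claim that something is new, unique, unknown or untested is made for them only; others in the source may bear on it.

Series notes. Compound 1 `C#Cc1cn([C@@H]2O[C@H](CO)[C@@H](O)[C@H]2O)c2ncnc(NC)c12` and compound 2 `C#Cc1cn([C@@H]2O[C@H](CO)[C@@H](O)[C@H]2O)c2nc(C)nc(N)c12` both carry the ethynyl group but have their atoms joined differently; the difference between the two cores is not broken down here. In a functional assay on HeLa S3 cells (Homo sapiens) for antiproliferative activity, read by XTT assay, with a stated time of 72 h (a higher number here means a weaker inhibitor, a lower number a stronger inhibitor), compound 1 gives only a limit, > 20000 nM. Compound 2 likewise reaches only a limit in this assay, > 20000 nM. Compound 3 `Cc1nc(N)c2c(I)cn([C@@H]3O[C@H](CO)[C@@H](O)[C@H]3O)c2n1` is the iodo counterpart of compound 2, and in this assay compound 3 gives 4180 nM. The change from compound 2 to compound 3 is iodo in place of ethynyl on an aromatic carbon, and it made a step of an at least 4.7-fold lower number from compound 2 to compound 3 (0.67 log units; beyond the scatter); because compound 2 sits at the limit of > 20000 nM in this assay, at which 2 of the 3 values shown sit, only the lower bound of that step is known.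

Compound 4 `CNc1ncnc2c1c(I)cn2[C@@H]1O[C@H](CO)[C@@H](O)[C@H]1O` stands to compound 1 as compound 3 stands to compound 2: the change is iodo in place of ethynyl on an aromatic carbon, the same change at the same place. Among the compounds with values here, whether it carries over from one core to the other is untested, as only one measured pair holds it. For this assay the expected step for compound 4 is an at least 3.3-fold lower number from compound 1 to compound 4 (0.52 log units; beyond the scatter), resting on the step of an at least 4.7-fold lower number from compound 2 to compound 3 (0.67 log units; beyond the scatter). Because compound 1 rests at the limit of > 20000 nM in this assay, at which 2 of the 3 values shown sit, as well, the true size of the step from compound 1 cannot be fixed, and compound 4 may itself stay at the limit. In this assay compound 4 is estimated at 6000 nM, between 1500 nM and 20000 nM.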

Compound 4, half-maximal inhibitory concentration: > 20000 nM
Compound 4 was reported as a limit (the forecaster's own chance of this, stated with the estimate: 35%); middle value at least 3.3-fold (0.52 log units) away from the limit.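

No new step can be read between compound 1 and compound 4 in this assay because both compounds are reported only as limits: the limit of > 20000 nM in this assay, at which 3 of the 4 values shown sit.

The compounds shown leave open how large the change of iodo in place of ethynyl on an aromatic carbon is on the core of compound 1, and whether the step seen on the core of compound 2 carries over to it.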